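Swapping 2-Hydroxyphenyl for 4-(Methylsulfanyl)phenyl in a Hydrazone

A few compounds are considered here, and "the series" means these few. Any claim that something is new, unique, unknown or untested is made for them only; others in the source may bear on it.

Compound 3 `O=C(COc1cccc2ccccc12)N/N=C/c1ccccc1O` was tested in an ADME assay on HEL cells (Homo sapiens) for cytotoxicity (on this read-out higher numbers stand for lower toxicity in this test and lower numbers for higher toxicity in this test), where compound 3 gives 20 ug/mL. Its closest neighbour on the numbers is compound 2 `O=C(COc1cccc2ccccc12)N/N=C/c1ccc([N+](=O)[O-])cc1`, which in this assay gives 20 ug/mL, so the two stand level at the digits shown. Compound 1 `O=C(COc1cccc2ccccc12)N/N=C/c1ccccc1Br` returns only a limit of the assay, >= 20 ug/mL. Within the data shown here, the one measured step, a number no higher from compound 1 to compound 3 (the limit leaves the size open), is of unreadable size, as the limit involved is the one described by the limit of >= 20 ug/mL in this assay, at which 1 of the 3 values shown sits.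

Compound 4 `CSc1ccc(/C=N/NC(=O)COc2cccc3ccccc23)cc1` has not yet been measured. It differs from compound 3 by 4-(methylsulfanyl)phenyl in place of 2-hydroxyphenyl on a carbon with a double bond to nitrogen. Among the measured compounds shown here, no measured step exchanges one ring substituent for a methylsulfanyl group, so only the general spread of the three compounds, all at or near one level in this assay, bears on it. Compound 4 is therefore expected to show no change at the digits printed from compound 3 to compound 4 (within the scatter), no step beyond the scatter. The estimate for compound 4 in this assay is 20 ug/mL, with a range from 10 ug/mL to 40 ug/mL.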

Compound 4, minimum cytotoxic concentration: >= 100 ug/mL
Compound 4: a limit, no number; the forecaster's own chance of this, stated with the estimate: 35%; at least 5.0-fold (0.69 log units) between middle value and limit.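

In this assay, 4-(methylsulfanyl)phenyl in place of 2-hydroxyphenyl gives an at least 5.0-fold higher number from compound 3 to compound 4 (0.69 log units; beyond the scatter), and methylsulfanyl in place of nitro on an aromatic carbon gives an at least 5.0-fold higher number from compound 2 to compound 4 (0.69 log units; beyond the scatter); these are the first readable steps among the compounds shown that lie beyond the scatter, both towards lower toxicity in this test. Among these compounds, compound 2 and compound 3 had stood level, so the earlier compounds gave no sign that a change of ring substituent could move this read-out. The value of compound 4 is a limit of the assay, and the step from compound 1 to compound 4 cannot be read: the limit of >= 100 ug/mL in this assay, at which 1 of the 4 values shown sits.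

Going by these compounds, whether the step belongs to the methylsulfanyl group itself or to the loss of 2-hydroxyphenyl stays open. Also open, on these data alone, is how a methoxy group or an amine in place of methylsulfanyl on an aromatic carbon would read in this assay.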